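Swapping the Imidazole Headgroup for a Triazole

The compounds below may be only part of what the source reports. "The series", "measured", "known", "first", "only" and "open" are said of these compounds alone.

Compound 1 `CCO/C(O)=C1\C(COCCn2cc(N)n(C)c2=O)=NC(C)=C(C(=O)OC)C1c1ccccc1Cl`: 25.1 nM
Compound 2 `CCO/C(O)=C1\C(COCCN2CC(=O)NC2=O)=NC(C)=C(C(=O)OC)C1c1ccccc1Cl`: 20 nM
Compound 3 `CCO/C(O)=C1\C(COCCn2c(N)cnc2O)=NC(C)=C(C(=O)OC)C1c1ccccc1Cl`: 158 nM

These three compounds, measured in a functional assay (aorta) with Rattus norvegicus as the target (on this read-out higher numbers stand for weaker inhibition and lower numbers for stronger inhibition), share one core and differ only in the ring attached to the chain. Compound 3 gives the highest number of the three, so it is the weakest inhibitor among them: the step from compound 1 to compound 3 was a 6.3-fold higher number from compound 1 to compound 3 (0.80 log units; beyond the scatter) and the step from compound 2 to compound 3 was a 7.9-fold higher number from compound 2 to compound 3 (0.90 log units; beyond the scatter). Between the other two the change was a 1.3-fold lower number from compound 1 to compound 2 (0.10 log units; within the scatter).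

Compound 4 `CCO/C(O)=C1\C(COCCn2ccnn2)=NC(C)=C(C(=O)OC)C1c1ccccc1Cl` takes the next step from compound 3: 1H-1,2,3-triazol-1-yl in place of 5-amino-2-hydroxy-1H-imidazol-1-yl on a saturated chain carbon, two bonds along the chain from an oxygen on a saturated carbon. Both measured steps that bear on this position show that replacing the 5-amino-2-hydroxy-1H-imidazol-1-yl ring by a different five-membered ring, whether aromatic as in compound 1 or non-aromatic as in compound 2, lowers the number by a modest amount. Among the measured compounds shown here, the 1H-1,2,3-triazol-1-yl ring is therefore expected to behave more like the rings of compound 1 and compound 2 than like that of compound 3, though no step with exactly this ring has been measured. The step from compound 3 to compound 4 is expected to be a 4.0-fold lower number from compound 3 to compound 4 (0.60 log units; beyond the scatter). Compound 4 is estimated at 40 nM, with a likely range from 15 nM to 120 nM.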

Compound 4, half-maximal inhibitory concentration: 15.9 nM
Compound 4: the middle estimate sits 2.5-fold (0.40 log units) above what was measured, and the stated range covers the measured number.
By their numbers in this assay, from the lowest: compounds 4, 2 and 1 (each within the scatter of the next); then compound 3.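

In this assay, moving to the 1H-1,2,3-triazol-1-yl ring gave a 9.9-fold lower number from compound 3 to compound 4 (1.00 log units; beyond the scatter), which shows that a ring with 0 hydrogen-bond donors, carrying neither the amino nor the hydroxy group of compound 3, can give a number in the same low group as compound 1 and compound 2. The new ring cannot be told apart from the other two, with a 1.3-fold lower number from compound 2 to compound 4 (0.10 log units; within the scatter) and a 1.6-fold lower number from compound 1 to compound 4 (0.20 log units; within the scatter) both lying within the scatter, so aromatic and non-aromatic rings of different sizes all fit this position and only the 5-amino-2-hydroxy-1H-imidazol-1-yl ring of compound 3 stands apart. Nothing measured here accounts for why that one ring gives the higher number.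

The compounds shown leave open whether a six-membered ring such as pyridine, a simple amine or a carboxylic acid at this place would stay in the same low group. They also leave open whether the isomeric 1H-1,2,4-triazol-1-yl ring, or a propyl chain in place of the ethyl link to the ring, would hold the number there.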